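The source may hold more compounds than are shown below. What is called first, only, known or untested is meant among the compounds shown, and "the series" means these compounds.

Measured so far in a functional assay on T47D cells (Homo sapiens) for activation; a lower number here means that less compound is needed, a higher number that more compound is needed for the effect:

- compound 1 `CCNc1ccc2c(c1)OC(N)=C(C#N)C2c1cc(Br)c(OC)c(OC)c1`: 14000000 nM
- compound 2 `CCNc1ccc2c(c1)OC(N)=C(C#N)C2c1cc(OC)c(OC)c(OC)c1`: 49000000 nM
- compound 3 `COc1cncc(C2C(C#N)=C(N)Oc3cc(OC)ccc32)c1`: 47000000 nM

Compound 2 gives the highest number of the three, but compound 3 sits within the scatter of it, so the two cannot be ordered. For the measured compounds named here, the one step beyond the scatter is a 3.5-fold higher number from compound 1 to compound 2 (0.54 log units; beyond the scatter), a modest rise.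

Compound 4 `CCNc1ccc2c(c1)OC(N)=C(C#N)C2c1cc(OC)cc(OC)c1` differs from compound 2 by hydrogen in place of methoxy on an aromatic carbon. Going by the values given here, no measured step removes a methoxy group from this ring; the only change recorded on the same ring is a 3.5-fold higher number from compound 1 to compound 2 (0.54 log units; beyond the scatter), which exchanged one substituent for another and stayed modest. That step bears on the change to compound 4 only loosely, and it gives no reason to expect a large movement in either direction in this assay. The expectation is therefore a step of roughly a 1.2-fold lower number from compound 2 to compound 4 (0.09 log units; within the scatter), that is, no change clearly beyond the scatter. Compound 4 is estimated at 40000000 nM, with a range from 12000000 nM to 130000000 nM.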

Compound 4, half-maximal effective concentration: 61700000 nM
Compound 4: middle estimate off by 1.5-fold (0.19 log units), on the low side, and the stated range covers the measured number.
By their numbers in this assay, from the lowest: compound 1; then compounds 3, 2 and 4 (each within the scatter of the next).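

In this assay the methoxy ortho to two methoxy groups gives way to hydrogen with a 1.3-fold higher number from compound 2 to compound 4 (0.10 log units; within the scatter) and this position therefore shows no measurable preference between the two in this pair. For the compounds shown here, the only step beyond the scatter so far is a 3.5-fold higher number from compound 1 to compound 2 (0.54 log units; beyond the scatter) and it concerns a different exchange, bromo to methoxy, at another place on the same ring. Losing this methoxy group, with its 2 heavy atoms and 1 hydrogen-bond acceptor, thus leaves the number within the scatter of compound 2, which the earlier compounds could not show.

No measurement at hand offers an explanation for this result.

On these data alone, whether a hydroxyl group, an amine or a longer chain such as propoxy at this position would move the number beyond the scatter remains open. So does whether hydrogen would be equally tolerated at the other two methoxy positions.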